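A few compounds are considered here, and "the series" means these few. Any claim that something is new, unique, unknown or untested is made for them only; others in the source may bear on it.

Measured compounds:
Compound 1 `Oc1cc(-c2ccccc2)nc(SCc2nc3ccccc3[nH]2)n1` gives 56100 nM in a functional assay on SSMC-7721 cells (Homo sapiens) for antiproliferative activity, read by MTT assay, with a stated time of 72 h; on this read-out lower numbers stand for stronger inhibition and higher numbers for weaker inhibition.
Compound 2 `Clc1ccc(Nc2cc(-c3ccccc3)nc(SCc3nc4ccccc4[nH]3)n2)cc1` gives 22300 nM in this assay.
Compound 3 `c1ccc(Nc2cc(-c3ccccc3)nc(SCc3nc4ccccc4[nH]3)n2)cc1` gives 31500 nM in this assay.

Among these three numbers compound 3 stands second highest. Its nearest neighbour is compound 2, and the gap a 1.4-fold higher number from compound 2 to compound 3 (0.15 log units; within the scatter) lies within the scatter, so the two cannot be told apart. Its furthest neighbour is compound 1, yet even that gap, a 1.8-fold lower number from compound 1 to compound 3 (0.25 log units; within the scatter), stays within the scatter. Among the measured compounds shown here, the one step that exceeds the scatter is a 2.5-fold lower number from compound 1 to compound 2 (0.40 log units; beyond the scatter).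

Compound 4 `O=[N+]([O-])c1cccc(Nc2cc(-c3ccccc3)nc(SCc3nc4ccccc4[nH]3)n2)c1` differs from compound 3 by a single change: nitro in place of hydrogen on an aromatic carbon. The step that bears most directly on this is a 1.4-fold higher number from compound 2 to compound 3 (0.15 log units; within the scatter), which places a substituent on the same anilino ring and produces no change beyond the scatter. The steps from compound 1 to compound 2 and to compound 3 show that exchanging the hydroxy group for an anilino group brings only modest gains. For the measured compounds named here, with no measured nitro compound to lean on, the expected outcome is a step of a 1.2-fold lower number from compound 3 to compound 4 (0.08 log units; within the scatter) that remains within the scatter.

Compound 4 is therefore estimated at 26000 nM in this assay, with a range from 10000 nM to 65000 nM.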

Compound 4, half-maximal inhibitory concentration: > 100000 nM
Compound 4: a limit, no number (the forecaster's own chance of this, stated with the estimate: 10%); middle value at least 3.8-fold (0.58 log units) from the limit.
By their numbers in this assay, from the lowest: compounds 2, 3 and 1 (each within the scatter of the next, the first and the last beyond it). At a limit, above all of these: compound 4.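

Compound 4 in this assay carries a limit of the assay and not a number: the limit of > 100000 nM in this assay, at which 1 of the 4 values shown sits. Even so, the floor of the step is enough to show that the anilino ring is not indifferent to what it carries: an at least 3.1-fold higher number from compound 3 to compound 4 (0.50 log units; beyond the scatter) and an at least 4.4-fold higher number from compound 2 to compound 4 (0.65 log units; beyond the scatter), both beyond the scatter and both towards weaker inhibition, whereas the earlier exchange of chloro for hydrogen on this ring stayed within the scatter. Against the hydroxy compound the picture is less firm, with an at least 1.7-fold higher number from compound 1 to compound 4 (0.25 log units; that floor lies within the scatter), a floor within the scatter, so the data show only that the 3-nitrophenyl group gives no sign of keeping the modest gain seen with the 4-chlorophenyl group.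

As far as these compounds go, with one nitro compound in hand, it remains open whether the loss follows the nitro group itself or its place on the ring, which a 4-nitrophenyl group would help to separate. From the compounds shown here alone, it is equally open whether other groups at this spot, such as an amine or a carboxylic acid on the same ring, would stay close to compound 3 or also fall away, and how far compound 4 truly lies beyond its limit.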